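Methyl in Place of Methoxy: Expected Loss of Solubility

The source may hold more compounds than are shown below. What is called first, only, known or untested is meant among the compounds shown, and "the series" means these compounds.

Compound 1 `COc1ccc(O)c(C(=O)Nc2ccc([N+](=O)[O-])cc2Cl)c1` and compound 2 `Cc1ccc(O)c(C(=O)Nc2ccc([N+](=O)[O-])cc2Cl)c1` share one core, while compound 3 `COc1ccc(NC(=O)c2cc(Cl)ccc2O)cc1` and compound 4 `Cc1ccc(NC(=O)c2cc(Cl)ccc2O)cc1` share another; the difference between the two cores is not broken down here. In a physicochemical assay for solubility (a higher number here means a more soluble compound, a lower number a less soluble compound), compound 1 gives 2.1 ug/mL. Compound 2 returns only a limit of the assay rather than a number, < 1 ug/mL. Compound 2 thus sits at the limit of < 1 ug/mL in this assay, at which 1 of the 3 values shown sits. The step of an at least 2.1-fold lower number from compound 1 to compound 2 (0.32 log units; beyond the scatter) accompanies the change (methyl in place of methoxy on an aromatic carbon). In this assay compound 3 gives 2.8 ug/mL, which lies within the scatter of the number for compound 1. Compound 4 carries the same kind of change, (methyl in place of methoxy on an aromatic carbon); the surroundings differ, since in compound 1 the site is meta to a large group and para to a hydroxy group, whereas in compound 3 it is para to a large group. The expected step of a 2.3-fold lower number from compound 3 to compound 4 (0.37 log units; beyond the scatter) rests on the measured step of an at least 2.1-fold lower number from compound 1 to compound 2 (0.32 log units; beyond the scatter). Compound 4 is therefore estimated to give 1.2 ug/mL in this assay, between 0.5 ug/mL and 2.5 ug/mL, with a real chance that only a limit is reported.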

Compound 4, solubility: < 1 ug/mL
Compound 4 gave a limit, no number; the forecaster's own chance of this, stated with the estimate: 40%; middle value at least 1.2-fold (0.07 log units) from the limit.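

In this assay the change of methyl in place of methoxy on an aromatic carbon gave an at least 2.8-fold lower number from compound 3 to compound 4 (0.44 log units; beyond the scatter), and in the other core it gave an at least 2.1-fold lower number from compound 1 to compound 2 (0.32 log units; beyond the scatter); the direction of the step therefore carried over from one core to the other, and both steps lie beyond the scatter. Compound 2 and compound 4 each end at a limit of the assay and not at a number: the limit of < 1 ug/mL in this assay, at which 2 of the 4 values shown sit. From the compounds shown here alone, both steps are thus only bounds, so the true size of the change remains unknown in either core, and these two pairs cannot show whether it is equal in both or extends to any further core.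

The compounds shown leave open what an amine, a carboxylic acid or a longer chain such as ethoxy would give in place of the methoxy in this assay. They also leave open whether the same step would appear with the methyl elsewhere on the ring.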